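The source may hold more compounds than are shown below. What is called first, only, known or untested is meant among the compounds shown, and "the series" means these compounds.

Working notes on the series. In an assay on microsomes from liver for inhibition of 3-hydroxy-3-methylglutaryl-coenzyme A reductase (Rattus norvegicus) (a lower number here means a stronger inhibitor, a higher number a weaker inhibitor), compound 1 `CC(C)c1c(C(=O)NCc2ccccc2)nn(-c2ccc(F)cc2)c1OC[C@@H](O)C[C@@H](O)CC(=O)O` gives 3.8 nM, compound 2 `CC(C)c1c(C(=O)N(C)Cc2ccccc2)nn(-c2ccc(F)cc2)c1OC[C@@H](O)C[C@@H](O)CC(=O)O` gives 5.2 nM, and compound 3 `Cc1cccc(CNC(=O)c2nn(-c3ccc(F)cc3)c(OC[C@@H](O)C[C@@H](O)CC(=O)O)c2C(C)C)c1` gives 4.9 nM. Compound 3 thus stands second highest of the three numbers, nearest compound 2 and furthest from compound 1, with every gap inside the scatter. Among the measured compounds shown here, the steps so far are all small: a 1.4-fold higher number from compound 1 to compound 2 (0.14 log units; within the scatter), a 1.3-fold higher number from compound 1 to compound 3 (0.11 log units; within the scatter), and a 1.1-fold lower number from compound 2 to compound 3 (0.03 log units; within the scatter). The next compound is compound 4 `COc1ccc(CNC(=O)c2nn(-c3ccc(F)cc3)c(OC[C@@H](O)C[C@@H](O)CC(=O)O)c2C(C)C)cc1`, which differs from compound 3 by 4-methoxyphenyl in place of 3-methylphenyl on a saturated chain carbon bound to an amide-type nitrogen. For the measured compounds named here, the steps that bear on it are the change of a substituent on the aromatic ring of the benzyl group, as in a 1.3-fold higher number from compound 1 to compound 3 (0.11 log units; within the scatter), and the change of the whole benzyl amide end, as in a 1.1-fold lower number from compound 2 to compound 3 (0.03 log units; within the scatter); both stayed within the scatter, so no step beyond the scatter is expected in this assay, in either direction. For compound 4 the estimate is 5 nM, in the range 2.5 nM to 10 nM, which means an expected step of a 1.0-fold higher number from compound 3 to compound 4 (0.01 log units; within the scatter).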

Compound 4, half-maximal inhibitory concentration: 12 nM
Estimate against measurement, compound 4: 2.4-fold (0.38 log units) below; the whole stated range lies below it.
By their numbers in this assay, from the lowest: compounds 1, 3 and 2 (each within the scatter of the next); then compound 4.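

In this assay, the substituted benzyl end now shows a step beyond the scatter: a 2.4-fold higher number from compound 3 to compound 4 (0.39 log units; beyond the scatter) for 4-methoxyphenyl in place of 3-methylphenyl on a saturated chain carbon bound to an amide-type nitrogen, whereas the methyl step (a 1.3-fold higher number from compound 1 to compound 3 (0.11 log units; within the scatter)) stayed within it. Adding a methoxy group to the aromatic ring gives a 3.2-fold higher number from compound 1 to compound 4 (0.50 log units; beyond the scatter) and (4-methoxybenzyl)amino in place of benzyl(methyl)amino on a carbonyl carbon gives a 2.3-fold higher number from compound 2 to compound 4 (0.36 log units; beyond the scatter), so this end tolerates change only in part, with all three new steps modest. No measurement at hand accounts for this loss.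

Compound 3 and compound 4 differ in both the group and its ring location, so these two effects remain unseparated. The 3-methoxybenzyl and 4-methylbenzyl amides would separate them, and a 4-chlorobenzyl amide would test whether the step is specific to methoxy.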